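Swapping Selenium for Sulfur on Two Paired Cores

The compounds below may be only part of what the source reports. "The series", "measured", "known", "first", "only" and "open" are said of these compounds alone.

Compound 1 `C[Se]/C(=N\C(=O)c1cc2ccccc2s1)NC(=O)c1cc2ccccc2s1` and compound 2 `CS/C(=N\C(=O)c1cc2ccccc2s1)NC(=O)c1cc2ccccc2s1` share one core and differ in a single spot: a group of 2 heavy atoms (1 carbon, 1 sulfur; no ring) in place of a group of 2 heavy atoms (1 carbon, 1 selenium; no ring), on a carbon with a double bond to nitrogen. In a functional assay on K562 cells (Homo sapiens) for cytotoxicity, read by MTT assay, with a stated time of 72 h (a lower number here means a stronger inhibitor of growth, a higher number a weaker inhibitor of growth), compound 1 gives 32400 nM, and compound 2 gives 34700 nM. Going from one to the other the measurement shows a 1.1-fold higher number from compound 1 to compound 2 (0.03 log units; within the scatter), so these two numbers cannot be told apart by this assay.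

Compound 3 `C[Se]/C(=N\C(=O)c1cnc2ccccc2c1)NC(=O)c1cnc2ccccc2c1` is built on a different core; how that core differs from the core of compound 1 is not broken down here. In this assay, going by the values given here, compound 3 gives 3800 nM, the lowest of the three numbers so far. Compound 4 `CS/C(=N\C(=O)c1cnc2ccccc2c1)NC(=O)c1cnc2ccccc2c1` has not yet been measured. It differs from compound 3 in exactly one place: a group of 2 heavy atoms (1 carbon, 1 sulfur; no ring) in place of a group of 2 heavy atoms (1 carbon, 1 selenium; no ring), on a carbon with a double bond to nitrogen. Among the compounds with values here, the surroundings of that place are described in the same words for both pairs, so this is the same change as the one between compound 1 and compound 2.

Because that change earlier gave a 1.1-fold higher number from compound 1 to compound 2 (0.03 log units; within the scatter), the step expected here is estimated as a 1.1-fold higher number from compound 3 to compound 4 (0.04 log units; within the scatter). This rests on one earlier pair on a different core, so a larger move in either direction cannot be ruled out. Compound 4 is therefore expected to give about 4200 nM in this assay, with a likely range from 2000 nM to 9000 nM.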

Compound 4, concentration for 50% growth inhibition: 65800 nM
For compound 4 the middle estimate is 16-fold (1.19 log units) below the measured one, outside the stated range (above it).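

On the core of compound 3, replacing the group that carries selenium with methylsulfanyl in this assay gives a 17-fold higher number from compound 3 to compound 4 (1.24 log units; beyond the scatter), so on this core the swap clearly weakens growth inhibition. The step measured on the core of compound 1 therefore did not carry over to this second core, and the size of this change depends on the core that carries it: the same change on two cores in this assay, a 1.1-fold higher number (0.03 log units; within the scatter) from compound 1 to compound 2 and a 17-fold higher number (1.24 log units; beyond the scatter) from compound 3 to compound 4, 16-fold (1.21 log units) apart, beyond the scatter of two such steps

This does not show which feature of the two cores produces the difference, and two pairs are too few to give a rule for how the swap will behave on any other core. The result also applies only to this one cell assay, so it says nothing about whether the same gap would appear in other cells or under other conditions.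

The compounds shown leave open how a methoxy group, a longer chain such as ethylsulfanyl, or an amine on that same carbon would compare with the group carrying selenium and with methylsulfanyl on each core. They also leave open whether a third core would behave like the core of compound 1, with no readable step, or like the core of compound 3, with a large one.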